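The source may hold more compounds than are shown below. What is called first, only, known or untested is meant among the compounds shown, and "the series" means these compounds.

Compound 2 `Cn1c(-c2ccc(NC(=O)CSc3nc4ccccc4o3)cc2)nc(-c2ccccc2)c1-c1ccccc1` and compound 1 `Cn1c(-c2ccc(NC(=O)CCl)cc2)nc(-c2ccccc2)c1-c1ccccc1` share the same core and differ in one place: a number 26.1 percentage points higher from compound 1 to compound 2 (beyond the scatter). In a functional assay on HT-29 cells (Homo sapiens) for cytotoxicity, read by MTT assay, with a stated time of 24 h, tested at 32 ug/mL (on this read-out higher numbers stand for a stronger effect at the one concentration tested and lower numbers for a weaker effect), compound 2 gives 79.3%, the higher of the two numbers shown, while compound 1 gives 53.2%. Compound 3 `Cn1c(-c2ccc(NC(=O)CSc3nc4cc(Cl)ccc4o3)cc2)nc(-c2ccccc2)c1-c1ccccc1` is built from compound 2 by a single change: chloro in place of hydrogen on an aromatic carbon. No measured step touches this ring position, so nothing shown bears directly on it, and the step is expected to stay within the scatter: a number 0.7 percentage points higher from compound 2 to compound 3 (within the scatter). Compound 3 is therefore estimated at 80%, between 65% and 92%.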

Compound 3, a percentage reported as activity, at one concentration (the size of the read-out at that concentration, not a potency): 61.9%
Beside the measured number, compound 3's estimate is 18.1 percentage points above it; the measured number lies below the stated range.
By their numbers in this assay, from the lowest: compounds 1 and 3 (each within the scatter of the next); then compound 2.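

In this assay, this aromatic carbon is not a neutral place to substitute: chloro in place of hydrogen gives a number 17.4 percentage points lower from compound 2 to compound 3 (beyond the scatter). The gain seen with (1,3-benzoxazol-2-yl)sulfanyl does not carry over to (5-chloro-1,3-benzoxazol-2-yl)sulfanyl, which gives a number 8.7 percentage points higher from compound 1 to compound 3 (within the scatter). No measurement shown explains this drop. Still open, as far as these compounds go, is whether the drop belongs to chloro itself or to any group on this carbon. A methoxy group or an amine at the same place would help separate the two.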